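Methyl to methoxy on the pendant aryl ring

The source may report more compounds than this note shows. Statements on the series, on what has been measured and on what is new or still open speak of the compounds shown alone.

Compound 1 `Cc1ccc(C2=NN(C3=NC(c4ccccc4)CS3)C(c3ccc4ccccc4c3)C2)cc1` and compound 2 `COc1ccc(C2=NN(C3=NC(c4ccccc4)CS3)C(c3ccc4ccccc4c3)C2)cc1` share one core; compound 3 `Cc1ccc(C2=NN(C3=NC(=O)CS3)C(c3cccc4ccccc34)C2)cc1` and compound 4 `COc1ccc(C2=NN(C3=NC(=O)CS3)C(c3cccc4ccccc34)C2)cc1` share another. How the two cores differ is not broken down here. In a functional assay on HepG2 cells (Homo sapiens) for inhibition, read by CCK-8 assay, with a stated time of 48 h (a higher number here means a weaker inhibitor, a lower number a stronger inhibitor), compound 1 gives 14700 nM, compound 2 gives 12600 nM and compound 3 gives 8660 nM. The change methoxy in place of methyl on an aromatic carbon gave a 1.2-fold lower number from compound 1 to compound 2 (0.07 log units; within the scatter). The same change, (methoxy in place of methyl on an aromatic carbon), leads to compound 4, which is not yet measured in this assay. Since the surroundings of the changed carbon read the same in both pairs, a step of like size is expected here; resting on a 1.2-fold lower number from compound 1 to compound 2 (0.07 log units; within the scatter), the expected step is a 1.2-fold lower number from compound 3 to compound 4 (0.06 log units; within the scatter). Compound 4 is therefore expected to give 7500 nM in this assay, with a likely range from 4000 nM to 14000 nM.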

Compound 4, half-maximal inhibitory concentration: 7850 nM
Beside the measured number, compound 4's estimate is 1.0-fold (0.02 log units) below it; low and high end bracket the measured number.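

In this assay, methoxy in place of methyl on an aromatic carbon gives a 1.1-fold lower number from compound 3 to compound 4 (0.04 log units; within the scatter). The two cores agree on this change: the same change on two cores in this assay, a 1.2-fold lower number (0.07 log units; within the scatter) from compound 1 to compound 2 and a 1.1-fold lower number (0.04 log units; within the scatter) from compound 3 to compound 4, 1.1-fold (0.02 log units) apart, within the scatter of two such steps. Both steps lie within the scatter, so the agreement is between two steps too small to read as effects, and it does not show that a step of real size would carry from one core to the other, or that this change would behave alike on any further core.

Open, going by these compounds, is whether an amine, a carboxylic acid or a longer chain such as ethoxy at the same place would move the number beyond the scatter on either core. Also open is what separates the two cores, as no pair shown differs between them in one place only.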